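From Benzyl to Acetyl on the Shared Core

The source may hold more compounds than are shown below. What is called first, only, known or untested is meant among the compounds shown, and "the series" means these compounds.

In a functional assay on U-87MG ATCC cells with U-87 MG (Homo sapiens) as the target, read by MTT assay, with a stated time of 24 h (on this read-out lower numbers stand for stronger inhibition and higher numbers for weaker inhibition), compound 1 (`COc1ccc(-c2cnc3cc(C)c(C)cc3n2)cc1O`) gives > 50000 nM, which is a limit of the assay and not a number. Among the compounds with values here, compound 2 (`Cc1cc2ncc(-c3ccc(OCc4ccccc4)c(O)c3)nc2cc1C`) reads 15900 nM, the only true number in this assay so far. Compound 3 (`CC(=O)Oc1ccc(-c2cnc3cc(C)c(C)cc3n2)cc1O`) carries acetyl in place of benzyl on an oxygen on an aromatic ring. Within the data shown here, one measured step bears on this change: phenyl in place of hydrogen on the saturated chain carbon gave an at least 3.1-fold lower number from compound 1 to compound 2 (0.49 log units; beyond the scatter), a modest gain at minimum that rests on a limit. Among the measured compounds shown here, compound 3 has lost that phenyl ring as well, though its acetyl has no measured counterpart, so a shift toward weaker inhibition is expected. The estimated step is a 2.2-fold higher number from compound 2 to compound 3 (0.34 log units; beyond the scatter). For compound 3 the expected value is 35000 nM, with an estimated range from 14000 nM to 75000 nM.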

Compound 3, half-maximal inhibitory concentration: 42300 nM
The estimate for compound 3 lay 1.2-fold (0.08 log units) below the measured number; the range from low to high includes it.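

In this assay, the exchange on an oxygen on an aromatic ring gives a 2.7-fold higher number from compound 2 to compound 3 (0.42 log units; beyond the scatter), so at this position benzyl now stands directly against acetyl, a group without a ring, and the step favours benzyl modestly. The exchange of methyl for acetyl at the same oxygen gives an at least 1.1-fold lower number from compound 1 to compound 3 (0.07 log units; that floor lies within the scatter), so no order can be set between these two groups. That step rests on the value of compound 1, which is a limit of the assay and not a number: the limit of > 50000 nM in this assay, at which 1 of the 3 values shown sits.

The compounds shown leave open whether the phenyl ring itself accounts for the lower number of compound 2, a question that a benzoyl group on this oxygen would bear on. They also leave open how a longer chain, such as phenylethyl, or a chain ending in an amine would read here.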